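The compounds below may be only part of what the source reports. "The series", "measured", "known", "first", "only" and "open" are said of these compounds alone.

Measured in a physicochemical assay for metabolic stability, read by HPLC and mass spectrometry, in phosphate buffer, at 37 degrees C, at pH 7.4; on this read-out lower numbers stand for a shorter-lived compound and higher numbers for a longer-lived compound:
- compound 1 `CN(C[C@@H]1[C@H](NC(=O)/C(=N\OC(C)(C)C(=O)O)c2csc(N)n2)C(=O)N1S(=O)(=O)O)C(=O)CN`: 212 h
- compound 2 `CC(C)(O/N=C(\C(=O)N[C@@H]1C(=O)N(S(=O)(=O)O)[C@@H]1CN1CCCCC1=O)c1csc(N)n1)C(=O)O`: 214 h

Compound 2, at 214 h, stands level with compound 1 within the scatter, and the two numbers are all there is so far. Next is compound 3 `CC(C)(O/N=C(\C(=O)N[C@@H]1C(=O)N(S(=O)(=O)O)[C@@H]1CN1CCNC1=O)c1csc(N)n1)C(=O)O`, with 2-oxoimidazolidin-1-yl in place of 2-oxopiperidin-1-yl on a saturated chain carbon bound to a saturated ring carbon.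

Among the measured compounds shown here, only one measured step bears on this place. The step of a 1.0-fold higher number from compound 1 to compound 2 (0.00 log units; within the scatter) lies within the scatter, although the groups exchanged there are quite different. For the measured compounds named here, no measured compound carries the entering group, so this is thin support. The expected step, a 1.0-fold lower number from compound 2 to compound 3 (0.01 log units; within the scatter), is nothing beyond the scatter, in neither direction. In this assay the estimate for compound 3 is 210 h, with an expected range from 115 h to 380 h.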

Compound 3, half-life: > 1000 h
Compound 3 was reported as a limit; the forecaster's own chance of this, stated with the estimate: 5%; at least 4.7-fold (0.67 log units) between middle value and limit.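

In this assay compound 3 gives > 1000 h as a limit of the assay, not a number. The saturated chain carbon bound to a saturated ring carbon looked unresponsive in the earlier pair, yet 2-oxoimidazolidin-1-yl gives an at least 4.6-fold higher number from compound 2 to compound 3 (0.66 log units; beyond the scatter) when it replaces 2-oxopiperidin-1-yl, and an at least 4.7-fold higher number from compound 1 to compound 3 (0.67 log units; beyond the scatter) when it replaces ((aminomethyl)carbonyl)(methyl)amino, so the read-out does depend on the group held at this place. Both steps rest on a limit: the limit of > 1000 h in this assay, at which 1 of the 3 values shown sits.

The change swaps a six-membered ring for a five-membered ring and also brings in a hydrogen-bond donor and a second ring nitrogen, and the compounds shown do not separate these differences. A 2-oxopyrrolidin-1-yl or 3-methyl-2-oxoimidazolidin-1-yl group at this place would pull them apart.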